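The source may report more compounds than this note shows. Statements on the series, on what has been measured and on what is new or still open speak of the compounds shown alone.

In a functional assay on MHCC97H cells (Homo sapiens) for antiproliferative activity, read by MTT assay, with a stated time of 48 h (a lower number here means a stronger inhibitor, a higher number a weaker inhibitor), compound 3 (`COc1ccc2c(/C=C/C(=O)c3cc(OC)c(OC)c(SC)c3)cn(C)c2c1`) gives 122 nM. This lies within the scatter of compound 2 (`COc1cc(C(=O)/C=C/c2c[nH]c3ccccc23)cc(SC)c1OC`) at 131 nM and of compound 1 (`COc1ccc2c(/C=C/C(=O)c3cc(N)c(OC)c(OC)c3)cn(C)c2c1`) at 198 nM, so the three cannot be ranked. Compound 4 (`COc1cc(C(=O)/C=C/c2cn(C)c3ccccc23)cc(SC)c1OC`) differs from compound 3 by hydrogen in place of methoxy on an aromatic carbon, part of a fused system of two rings: hydrogen in place of methoxy on an aromatic carbon. Going by the values given here, the one measured step, a 1.6-fold lower number from compound 1 to compound 3 (0.21 log units; within the scatter), stays within the scatter and concerns a different exchange, and no measured step covers this one. A shift beyond the scatter is therefore not expected in this assay, and the estimated step is a 1.1-fold higher number from compound 3 to compound 4 (0.03 log units; within the scatter). For compound 4 the expected value is 130 nM, with an estimated range of 50 nM to 320 nM.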

Compound 4, half-maximal inhibitory concentration: 150 nM
The estimate for compound 4 lay 1.2-fold (0.06 log units) below the measured number; the measured number falls inside the stated range.
By their numbers in this assay, from the lowest: compounds 3, 2, 4 and 1 (each within the scatter of the next).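

In this assay hydrogen in place of methoxy on the six-membered aromatic ring, part of a fused system of two rings, stays within the scatter (a 1.2-fold higher number from compound 3 to compound 4 (0.09 log units; within the scatter)), so this exchange at this position gives no readable change. Methyl in place of hydrogen on the aromatic nitrogen also stays within the scatter (a 1.1-fold higher number from compound 2 to compound 4 (0.06 log units; within the scatter)). Nothing given here explains either step. From the compounds shown here alone, whether a chlorine atom, a carboxylic acid or a longer alkoxy chain at this position would shift the number beyond the scatter remains open.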